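From Cyclopropyl to 4-Methoxycyclohexyl on the Shared Core

The source may report more compounds than this note shows. Statements on the series, on what has been measured and on what is new or still open speak of the compounds shown alone.

Measured in an ADME assay on microsomes from liver (Homo sapiens) for metabolic stability, read by LC-MS, using NADPH, with a stated time of 10 min, tested at 10 uM; on this read-out higher numbers stand for a longer-lived compound and lower numbers for a shorter-lived compound:
Compound 1 `Nc1ncnc2c1c(Oc1cc(C(F)(F)F)ccn1)nn2C1CC1`: > 2.41 h, a limit of the assay.
Compound 2 `Nc1ncnc2c1c(Oc1cc(O)ccn1)nn2C1CCC(F)(F)CC1`: > 2.41 h, a limit of the assay.
Compound 3 `CC(C)(C)n1nc(Oc2cc(Cl)ccn2)c2c(N)ncnc21`: 1 h.

Compound 1 gives no number in this assay, only a limit (the limit of > 2.41 h in this assay, at which 2 of the 3 values shown sit). Compound 3 is the only one of the three with a number, at 1 h. Compound 4 `CO[C@H]1CC[C@@H](n2nc(Oc3cc(C(F)(F)F)ccn3)c3c(N)ncnc32)CC1` keeps the core of compound 1 and the group attached to it through oxygen, but changes the group on the ring nitrogen. The change is 4-methoxycyclohexyl in place of cyclopropyl on an aromatic nitrogen In words, 4-methoxycyclohexyl replaces cyclopropyl on an aromatic nitrogen, and the entering group brings two defined stereocentres.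

Within the data shown here, no two measured compounds differ in one place only, so the size of this change has not been seen directly. Because compound 3 gives 1 h it offers a single numerical reference, though it differs from compound 1 in more than one place. A moderate fall in half-life is expected, and compound 4 may still reach the limit. The expected change is an at least 1.8-fold lower number from compound 1 to compound 4 (0.26 log units; that floor lies within the scatter). For compound 4 the estimated half-life is 1.3 h, with an expected range of 0.5 h to 3 h.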

Compound 4, half-life: 0.317 h
Estimate against measurement, compound 4: 4.1-fold (0.61 log units) above; measured number below the stated range.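

Across the shared core, 4-methoxycyclohexyl in place of cyclopropyl on an aromatic nitrogen gives an at least 7.6-fold lower number from compound 1 to compound 4 (0.88 log units; beyond the scatter) in this assay, and this shows that a change at this position alone can move the half-life, which no pair among the earlier compounds could show. The value of compound 1, > 2.41 h, is a limit of the assay, so the step is a floor and not a full size. That limit is shared within this small set: the limit of > 2.41 h in this assay, at which 2 of the 4 values shown sit.

The step joins the six-membered ring, the oxygen of the methoxy group and the two defined stereocentres in a single change, so the compounds shown cannot say which of these carries it. Going by these compounds, it also remains open whether a plain cyclohexyl group, a 4-hydroxycyclohexyl group, the other stereoisomer of 4-methoxycyclohexyl or a small open chain such as isopropyl on the same nitrogen would stay closer to compound 1 or to compound 4.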